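Removing a chain double bond from compound 3

The source may hold more compounds than are shown below. What is called first, only, known or untested is meant among the compounds shown, and "the series" means these compounds.

- compound 1 `C[C@H](CCCOc1ccccc1CN(C)C(=O)c1ccc(-c2ccco2)cc1)CC(=O)O`: 77700 ng.h/mL
- compound 2 `CN(Cc1ccccc1OCCC/C=C/C(=O)O)C(=O)c1ccc(-c2ccco2)cc1`: 750 ng.h/mL
- compound 3 `C/C(=C\CCCOc1ccccc1CN(C)C(=O)c1ccc(-c2ccco2)cc1)C(=O)O`: 1300 ng.h/mL

In an ADME assay on the whole organism (strain CD-1) for pharmacokinetics, with Mus musculus as the target, at a dose of 3 mg/kg by the intravenous route (on this read-out lower numbers stand for lower exposure and higher numbers for higher exposure at the dose given), compound 3 belongs to the lower pair of these three: a 1.7-fold higher number from compound 2 to compound 3 (0.24 log units; within the scatter), and a 60-fold lower number from compound 1 to compound 3 (1.78 log units; beyond the scatter). Compound 4 `CC(CCOc1ccccc1CN(C)C(=O)c1ccc(-c2ccco2)cc1)CCC(=O)O` alters its chain: 3-carboxy-1-methylpropyl in place of 3-carboxybut-2-en-1-yl on a saturated chain carbon, two bonds along the chain from an oxygen on an aromatic ring. That puts 3-carboxy-1-methylpropyl in place of 3-carboxybut-2-en-1-yl, on a saturated chain carbon, two bonds along the chain from an oxygen on an aromatic ring. One double bond goes, and the chain of compound 1 lacks one too. Among the measured compounds shown here, two measured steps bear on this: a 100-fold lower number from compound 1 to compound 2 (2.02 log units; beyond the scatter), and a 60-fold lower number from compound 1 to compound 3 (1.78 log units; beyond the scatter). Both were large, so a sizeable rise is expected, here estimated as a 7.7-fold higher number from compound 3 to compound 4 (0.89 log units; beyond the scatter). The chain of compound 4 still differs from that of compound 1, so no full return to 77700 ng.h/mL is assumed. For compound 4 the estimate is 10000 ng.h/mL, with an expected range of 2000 ng.h/mL to 60000 ng.h/mL.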

Compound 4, area under the concentration-time curve: 11800 ng.h/mL
The estimate for compound 4 lay 1.2-fold (0.07 log units) below the measured number, within the range that was stated.
By their numbers in this assay, from the lowest: compounds 2 and 3 (each within the scatter of the next); then compound 4; then compound 1.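

In this assay, losing the chain double bond pays off against both unsaturated compounds (a 9.1-fold higher number from compound 3 to compound 4 (0.96 log units; beyond the scatter); a 16-fold higher number from compound 2 to compound 4 (1.20 log units; beyond the scatter)). So a saturated chain alone lifts the number, yet it does not settle it: with 3-carboxy-1-methylpropyl in place of 2-(carboxymethyl)propyl, the arrangement of a saturated chain also counts (a 6.6-fold lower number from compound 1 to compound 4 (0.82 log units; beyond the scatter)). Nothing measured here explains these differences. Still open, as far as these compounds go, is how an unbranched saturated chain would compare, or a longer chain, and whether an amide could stand in place of the carboxylic acid.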